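Shifting the trifluoromethyl within the aryl group of compound 2

The compounds below may be only part of what the source reports. "The series", "measured", "known", "first", "only" and "open" are said of these compounds alone.

Compound 2 `O=C(CSc1ccc([N+](=O)[O-])cc1)N1N=C(c2cc3ccccc3oc2=O)C[C@@H]1c1ccc(C(F)(F)F)cc1` carries a 4-nitrophenyl on a sulfur and a 4-(trifluoromethyl)phenyl on a saturated ring carbon. In a functional assay on SGC-7901 cells (Homo sapiens) for cytotoxicity, read by MTT assay, with a stated time of 48 h (on this read-out lower numbers stand for stronger inhibition and higher numbers for weaker inhibition), compound 2 gives 8510 nM, the highest of the three numbers. Compound 1 `O=C(CSc1ncccn1)N1N=C(c2cc3ccccc3oc2=O)C[C@@H]1c1ccc(C(F)(F)F)cc1` gives 4390 nM in this assay, and compound 3 `CCCCSCC(=O)N1N=C(c2cc3ccccc3oc2=O)C[C@@H]1c1ccc(C(F)(F)F)cc1` gives 2910 nM. The steps of a 1.9-fold higher number from compound 1 to compound 2 (0.29 log units; within the scatter), a 1.5-fold lower number from compound 1 to compound 3 (0.18 log units; within the scatter) and a 2.9-fold lower number from compound 2 to compound 3 (0.47 log units; beyond the scatter) all vary the group on the sulfur. Compound 4 `O=C(CSc1ccc([N+](=O)[O-])cc1)N1N=C(c2cc3ccccc3oc2=O)C[C@@H]1c1ccccc1C(F)(F)F` differs from compound 2 elsewhere: 2-(trifluoromethyl)phenyl in place of 4-(trifluoromethyl)phenyl on a saturated ring carbon. Among the compounds with values here, no measured step changes this group, so nothing here indicates a direction, and no step beyond the scatter is expected: a 1.0-fold lower number from compound 2 to compound 4 (0.00 log units; within the scatter). Compound 4 is therefore expected to give 8500 nM, in the range 3000 nM to 25000 nM in this assay.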

Compound 4, half-maximal inhibitory concentration: 9770 nM
Compound 4: the middle estimate sits 1.1-fold (0.06 log units) below what was measured; the measured number falls inside the stated range.
By their numbers in this assay, from the lowest: compounds 3, 1, 2 and 4 (each within the scatter of the next, the first and the last beyond it).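

Replacing 4-(trifluoromethyl)phenyl with 2-(trifluoromethyl)phenyl on the saturated ring carbon gives a 1.1-fold higher number from compound 2 to compound 4 (0.06 log units; within the scatter) in this assay. Within the data shown here, this is the first reading at this position, since the earlier compounds varied only the group on the sulfur, and with 4-nitrophenyl on the sulfur the two placements of the trifluoromethyl cannot be told apart. No evidence is available that bears on this result. From the compounds shown here alone, it remains open whether a plain phenyl or a cyclohexyl on that carbon would read alike, and whether the same swap would hold with butyl or pyrimidin-2-yl on the sulfur.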